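Branching the amide chain of compound 3

The compounds below may be only part of what the source reports. "The series", "measured", "known", "first", "only" and "open" are said of these compounds alone.

Compound 3 `CCCC(=O)NC[C@@H]1C[C@H]1c1cccc2c1OC(CCC)N2` gives 0.04 nM in an assay on NIH3T3 cells with melatonin receptor type 1B (Homo sapiens) as the target (on this read-out lower numbers stand for stronger inhibition and higher numbers for weaker inhibition), the lowest number among the three measured; compound 2 `CCC1Nc2cccc([C@@H]3C[C@H]3CNC(=O)C(C)C)c2O1` gives 0.75 nM and compound 1 `CCC1Nc2cccc([C@@H]3C[C@H]3CNC(C)=O)c2O1` gives 0.88 nM, both well beyond the scatter above it. Compound 4 `CCCC1Nc2cccc([C@@H]3C[C@H]3CNC(=O)C(C)C)c2O1` differs from compound 3 by isopropyl in place of propyl on a carbonyl carbon. For the measured compounds named here, no measured pair sets propyl against isopropyl at this position; the nearest guide is a 1.2-fold lower number from compound 1 to compound 2 (0.07 log units; within the scatter), methyl to isopropyl on a carbonyl carbon, a step that stayed within the scatter. A change in branching of the same chain is therefore expected to move the number little. For compound 4 the expected step is a 1.3-fold higher number from compound 3 to compound 4 (0.10 log units; within the scatter). Compound 4 is expected to give 0.05 nM in this assay, within a range from 0.02 nM to 0.15 nM.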

Compound 4, inhibition constant: 0.28 nM
Estimate against measurement, compound 4: 5.6-fold (0.75 log units) below; the measured number lies above the stated range.
By their numbers in this assay, from the lowest: compound 3; then compound 4; then compounds 2 and 1 (each within the scatter of the next).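

In this assay, propyl to isopropyl on a carbonyl carbon gives a 7.0-fold higher number from compound 3 to compound 4 (0.85 log units; beyond the scatter) and so counts at this position, although methyl to isopropyl there gave only a 1.2-fold lower number from compound 1 to compound 2 (0.07 log units; within the scatter) in the earlier pair. The other chain matters too: methyl in place of hydrogen on a saturated chain carbon, two bonds along the chain from a saturated ring carbon, gives a 2.7-fold lower number from compound 2 to compound 4 (0.43 log units; beyond the scatter) with isopropyl held on the carbonyl carbon. No evidence at hand explains either step.

Still open, on these data alone, is whether a butyl chain or a cyclopropyl group on the carbonyl carbon keeps the number of compound 3 or moves it.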